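Removing the aromatic substituent: compound 3 to compound 4

The source may report more compounds than this note shows. Statements on the series, on what has been measured and on what is new or still open speak of the compounds shown alone.

Measured in a functional assay on aorta (Rattus norvegicus, strain Wistar); on this read-out lower numbers stand for smaller maximal responses and higher numbers for larger maximal responses:
compound 1 `Cc1ccc2c(c1)N(C1=CCCC1=O)CC(C)(C)S2`: 89%
compound 2 `CC(=O)c1ccc2c(c1)N(C1=CCCC1=O)CC(C)(C)S2`: 88%
compound 3 `CC(=O)Nc1ccc2c(c1)N(C1=CCCC1=O)CC(C)(C)S2`: 97%

The three measured compounds share one core and differ only in the group on the aromatic carbon. Compound 3 gives the highest of the three numbers, but a number 8 percentage points higher from compound 1 to compound 3 (within the scatter) and a number 9 percentage points higher from compound 2 to compound 3 (within the scatter) both lie within the scatter, so the three are not distinguished in this assay.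

Compound 4 `CC1(C)CN(C2=CCCC2=O)c2ccccc2S1` is not yet measured. Relative to compound 3 the change is hydrogen in place of acetamido on an aromatic carbon.

All three measured steps concern the same aromatic position: a number 1 percentage points lower from compound 1 to compound 2 (within the scatter), a number 8 percentage points higher from compound 1 to compound 3 (within the scatter) and a number 9 percentage points higher from compound 2 to compound 3 (within the scatter). None of them reached beyond the scatter, whether the group carried a carbonyl or an amide. Going by the values given here, no measured step covers removal of the substituent to hydrogen, so the expectation rests on the observation that the read-out in this assay has so far been insensitive to this position.

Compound 4 is therefore expected near 90%, with a range of 78% to 100%. The expected step is a number 7 percentage points lower from compound 3 to compound 4 (within the scatter), not beyond the scatter.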

Compound 4, largest response reached (Emax), in percent of the reference or control that the assay uses: 90%
Beside the measured number, compound 4's estimate shows no gap at the digits printed; the measured number falls inside the stated range.
By their numbers in this assay, from the lowest: compounds 2, 1, 4 and 3 (each within the scatter of the next).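

In this assay, removing the substituent altogether does not set compound 4 apart from any of the substituted compounds: a number 7 percentage points lower from compound 3 to compound 4 (within the scatter), a number 2 percentage points higher from compound 2 to compound 4 (within the scatter) and a number 1 percentage points higher from compound 1 to compound 4 (within the scatter). The earlier steps only exchanged one group for another, whereas these show that the read-out also stays within the scatter with hydrogen on this aromatic carbon, so neither methyl, acetyl nor acetamido is shown to be needed there. No supporting evidence bears on this result.

From the compounds shown here alone, it remains open whether a group of another kind on this carbon, such as an amine, a carboxylic acid or a longer chain, would move the maximal response beyond the scatter. Going by these compounds, all four compounds also keep the rest of the shared core unchanged, so the dependence of the response on those parts remains open too.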